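The source may report more compounds than this note shows. Statements on the series, on what has been measured and on what is new or still open speak of the compounds shown alone.

Compound 1 `CN(C)c1ccc2c(Oc3ccc(NC(=O)NCc4ccc(F)cc4)cc3)ncnc2c1` is a diaryl ether urea. Among the measured compounds shown here, in an ADME assay on the whole organism (Rattus norvegicus, strain Sprague-Dawley) for metabolic stability, read by LC-MS, with a stated time of 24 h, at a dose of 5 mg/kg by the intravenous route (a lower number here means that the compound disappears faster, a higher number that the compound lasts longer), compound 1 gives 3.3 h, the higher of the two numbers measured so far. For the measured compounds named here, compound 2 `COc1ccc(CNC(=O)Nc2ccc(Oc3ncnc4cc(N(C)C)ccc34)cc2)cn1` differs from it only in the group on the urea nitrogen, and in this assay compound 2 gives 1.2 h, so the one measured step is a 2.8-fold lower number from compound 1 to compound 2 (0.44 log units; beyond the scatter).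

Compound 3 `COc1ccc(NC(=O)Nc2ccc(Oc3ncnc4cc(N(C)C)ccc34)cc2)cc1` is the next compound to be tested. Going by the values given here, its change from compound 1 is 4-methoxyphenyl in place of 4-fluorobenzyl on an amide-type nitrogen, a different change from the one between compound 1 and compound 2: the linking chain carbon is gone and the ring now sits directly on the urea nitrogen, with a methoxy group instead of a fluorine. Among the compounds with values here, no measured pair covers this exact swap, so the step must be guessed with a wide margin. Because a 2.8-fold lower number from compound 1 to compound 2 (0.44 log units; beyond the scatter) moved the number down when the outer ring was exchanged, a modest downward step is expected for compound 3, a 1.7-fold lower number from compound 1 to compound 3 (0.22 log units; within the scatter). Compound 3 is therefore estimated at 2 h, with a likely range from 0.8 h to 5 h.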

Compound 3, half-life: 1.6 h
Beside the measured number, compound 3's estimate is 1.3-fold (0.10 log units) above it; the range from low to high includes it.
By their numbers in this assay, from the lowest: compounds 2 and 3 (each within the scatter of the next); then compound 1.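

In this assay, the step from a benzyl group to a phenyl group on the urea nitrogen, with methoxy taking the place of fluorine, is (a 2.1-fold lower number from compound 1 to compound 3 (0.31 log units; beyond the scatter)), so a second replacement of 4-fluorobenzyl also gives a lower number. The two replacements cannot be told apart, since (a 1.3-fold higher number from compound 2 to compound 3 (0.12 log units; within the scatter)) stays within the usual scatter even though the outer ring and its link to the urea nitrogen both differ. Among these three compounds, 4-fluorobenzyl therefore gives the highest number, but no measurement here bears on why.

From the compounds shown here alone, compound 3 changes the chain carbon and the ring substituent at once, so the share of each in the step remains unknown. A 4-fluorophenyl or a 4-methoxybenzyl group on the same nitrogen would separate the two changes.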